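Pyrazolyl chalcones against T47D growth: methoxy count on the aryl

The compounds below may be only part of what the source reports. "The series", "measured", "known", "first", "only" and "open" are said of these compounds alone.

Measured compounds:
compound 1 `COc1ccc(-c2cc(/C=C/C(=O)c3ccc(N)cc3)[nH]n2)cc1` – 9770 nM
compound 2 `COc1ccc(-c2cc(/C=C/C(=O)c3ccc(N)cc3)[nH]n2)cc1OC` – 26000 nM
compound 3 `COc1cc(C(=O)/C=C/c2cc(-c3cc(OC)c(OC)c(OC)c3)n[nH]2)cc(OC)c1OC` – 2570 nM

All three were run in a functional assay on T47D cells (Homo sapiens) for inhibition, read by sulforhodamine B assay, with a stated time of 48 h; a lower number here means a stronger inhibitor of growth, a higher number a weaker inhibitor of growth. Compound 3 has the lowest number of the three; compound 1 follows, and compound 2 is the furthest from it. The difference between the core of compound 2 and the core of compound 3 is not broken down here.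

For the measured compounds named here, the one counted step is hydrogen in place of methoxy on an aromatic carbon, which gave a 2.7-fold lower number from compound 2 to compound 1 (0.43 log units; beyond the scatter).

Compound 4 `COc1ccc(-c2cc(/C=C/C(=O)c3cc(OC)c(OC)c(OC)c3)[nH]n2)cc1OC` is not yet measured. It differs from compound 3 by hydrogen in place of methoxy on an aromatic carbon. This is the same kind of change as from compound 2 to compound 1, though the surroundings differ: in compound 3 the carbon that loses its methoxy is also meta to a methoxy group, which is not the case in compound 2. Placed beside the earlier step, the step from compound 3 to compound 4 in this assay is expected to be a 1.7-fold lower number from compound 3 to compound 4 (0.23 log units; within the scatter), a modest lowering resting on compound 2 to compound 1 giving a 2.7-fold lower number from compound 2 to compound 1 (0.43 log units; beyond the scatter) and on the margin that compound 3 already holds at 2570 nM. Compound 4 is therefore estimated at 1500 nM, with a range from 500 nM to 4500 nM.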

Compound 4, concentration for total growth inhibition: 3760 nM
Estimate against measurement, compound 4: 2.5-fold (0.40 log units) below; low and high end bracket the measured number.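

In this assay, hydrogen in place of methoxy on an aromatic carbon gives a 1.5-fold higher number from compound 3 to compound 4 (0.17 log units; within the scatter), so on this core the change has no effect that can be told from the scatter. The change therefore does not carry over in size from one core to the other: the same change on two cores in this assay, a 2.7-fold lower number (0.43 log units; beyond the scatter) from compound 2 to compound 1 and a 1.5-fold higher number (0.17 log units; within the scatter) from compound 3 to compound 4, 3.9-fold (0.59 log units) apart, beyond the scatter of two such steps. For the compounds shown here, with only one pair per core, this shows a dependence on the core for these two cases alone; it does not show which difference between the cores accounts for it, or how the change would behave on any further core.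

Still open, going by these compounds, is whether a hydroxyl group, an ethoxy group or a fluorine atom on the same aromatic carbon would give a step beyond the scatter on both cores. Also open, on these data alone, is whether any such replacement would follow the core of compound 1 or the core of compound 4 when carried across the series.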